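The source may hold more compounds than are shown below. What is called first, only, known or untested is meant among the compounds shown, and "the series" means these compounds.

Measured compounds:
Compound 1, `C/C(=N\Nc1nc(-c2ccc(Cl)cc2)cs1)c1cc2ccccc2o1`: 38100 nM
Compound 2, `C/C(=N\Nc1nc(-c2ccc(C)cc2)cs1)c1cc2ccccc2o1`: 21400 nM
Compound 3, `C/C(=N\Nc1nc(-c2cc3ccccc3o2)cs1)c1cc2ccccc2o1`: 34200 nM

All three were tested in a functional assay on PC-3 cells (Homo sapiens) for antiproliferative activity; a lower number here means a stronger inhibitor, a higher number a weaker inhibitor. Compound 3 stands second highest of the three numbers: the step of a 1.1-fold lower number from compound 1 to compound 3 (0.05 log units; within the scatter) is the smallest gap to it, and the step of a 1.6-fold higher number from compound 2 to compound 3 (0.20 log units; within the scatter) the largest. The three compounds share one core and differ only in a single group attached to it, and every difference among them lies within the scatter.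

Compound 4, `C/C(=N\Nc1nc(C)cs1)c1cc2ccccc2o1`, has not yet been measured. Going from compound 3 to compound 4, (methyl in place of 1-benzofuran-2-yl on an aromatic carbon). Among the measured compounds shown here, no measured step swaps an aromatic group for a methyl at this position; the steps that bear on it are the exchanges of one aromatic group for another at the same place, namely a 1.8-fold lower number from compound 1 to compound 2 (0.25 log units; within the scatter), a 1.1-fold lower number from compound 1 to compound 3 (0.05 log units; within the scatter) and a 1.6-fold higher number from compound 2 to compound 3 (0.20 log units; within the scatter). For the measured compounds named here, all three stay within the scatter, so the numbers so far show little dependence on which aromatic group sits there. Going by the values given here, removing the rings altogether is a larger change with no measured counterpart, so the uncertainty is wider. A modest step toward a higher number is expected, a 1.6-fold higher number from compound 3 to compound 4 (0.21 log units; within the scatter). Compound 4 is estimated to give 55000 nM in this assay, with an expected range from 17000 nM to 180000 nM.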

Compound 4, half-maximal inhibitory concentration: 8990 nM
The estimate for compound 4 lay 6.1-fold (0.79 log units) above the measured number, outside the stated range (below it).
By their numbers in this assay, from the lowest: compound 4; then compounds 2, 3 and 1 (each within the scatter of the next).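

In this assay the three aromatic groups at this place on the five-membered aromatic ring had looked interchangeable, but the much smaller methyl separates from all of them. Replacing 1-benzofuran-2-yl gives a 3.8-fold lower number from compound 3 to compound 4 (0.58 log units; beyond the scatter) and replacing 4-methylphenyl gives a 2.4-fold lower number from compound 2 to compound 4 (0.38 log units; beyond the scatter) while replacing 4-chlorophenyl gives a 4.2-fold lower number from compound 1 to compound 4 (0.63 log units; beyond the scatter) so all three comparisons point the same way, and none of the compounds shown goes against it. The position therefore does respond to change: which aromatic group sits there made little measurable difference, whereas exchanging any of them for a methyl without a ring moved the number beyond the scatter, and nothing available explains why this happens.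

A single small group cannot show how far this extends: an ethyl, a longer chain, a cyclopropyl ring, or an amine at the same carbon could give a number lower than, close to, or higher than that of compound 4. Even the best number here remains a single value in one cell line, so whether the same ranking holds in other cells also remains open.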